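The compounds below may be only part of what the source reports. "The series", "measured", "known", "first", "only" and "open" are said of these compounds alone.

Working notes on the series. All three measured compounds share one core and differ only in the group on the saturated chain carbon bound to an oxygen next to a carbonyl group. Compound 1 `COCCOC(=O)c1c(-c2ccc(OC)c(OC)c2)csc1N` gives 57% in an assay on isolated protein for inhibition of protein kinase C zeta type (Homo sapiens), with stated times of 1 h and 2.5 min, tested at 30 uM; on this read-out higher numbers stand for more inhibition at the one concentration tested (going by the name of the read-out) and lower numbers for less inhibition. Compound 2 `COc1ccc(-c2csc(N)c2C(=O)OCc2ccccc2C)cc1OC` gives 64% in this assay, and compound 3 `COc1ccc(-c2csc(N)c2C(=O)OCc2ccc(C)cc2)cc1OC` gives 50% in this assay. Compound 3 sits at the low end of the three numbers: the step of a number 14 percentage points lower from compound 2 to compound 3 (beyond the scatter) is beyond the scatter, whereas the step of a number 7 percentage points lower from compound 1 to compound 3 (within the scatter) and the step of a number 7 percentage points higher from compound 1 to compound 2 (within the scatter) are both within it.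

Compound 4 `COc1ccc(-c2csc(N)c2C(=O)OCc2ccncc2)cc1OC` is not yet measured. The change from compound 3 is pyridin-4-yl in place of 4-methylphenyl on a saturated chain carbon bound to an oxygen next to a carbonyl group. The measured steps at this place all concern exchanges of one carbon-only group for another, and none of them exceeds the modest size of a number 14 percentage points lower from compound 2 to compound 3 (beyond the scatter). Among the compounds with values here, no measured step introduces a ring with a hetero atom, so the direction of the change is open. On the data at hand, the step of no change at the digits printed from compound 3 to compound 4 (within the scatter) is expected to stay within the scatter, and compound 4 is estimated at 50% in this assay, with a range from 30% to 68%.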

Compound 4, a percentage reported as inhibition, at one concentration (the size of the read-out at that concentration, not a potency): 53%
For compound 4 the middle estimate is 3 percentage points below the measured one; low and high end bracket the measured number.
By their numbers in this assay, from the lowest: compounds 3, 4, 1 and 2 (each within the scatter of the next, the first and the last beyond it).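

Pyridin-4-yl brings the first ring with a hetero atom to the saturated chain carbon bound to an oxygen next to a carbonyl group, and in this assay the exchange for 4-methylphenyl, a number 3 percentage points higher from compound 3 to compound 4 (within the scatter), gives no difference that can be read. Within the data shown here, compound 4 also falls in with the earlier pattern of compound 3 against the other two esters: a number 4 percentage points lower from compound 1 to compound 4 (within the scatter) stays within the scatter, whereas a number 11 percentage points lower from compound 2 to compound 4 (beyond the scatter) goes beyond it, leaving 2-methylphenyl as the only group set apart from any other at this place. No evidence is at hand on what lies behind these numbers.

Going by these compounds, it remains open how a piperidin-4-yl ring or a carboxylic acid would read at this place. On these data alone, with each compound read at a single concentration in this assay, potencies also remain open.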